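A few compounds are considered here, and "the series" means these few. Any claim that something is new, unique, unknown or untested is made for them only; others in the source may bear on it.

Measured compounds: compound 1 `CCN(CC)Cc1ccc(-c2ccnc3ccc(-c4cnc(OC)c(NS(=O)(=O)c5ccc(F)cc5F)c4)cc23)cc1` with 4890 nM; compound 2 `COc1ncc(-c2ccc3nccc(-c4ccc(Cn5cncn5)cc4)c3c2)cc1NS(=O)(=O)c1ccc(F)cc1F` with "not determined" (no result reported).

In a functional assay on U-87MG ATCC cells (Homo sapiens) for cytotoxicity, read by MTT assay, with a stated time of 72 h (on this read-out lower numbers stand for stronger inhibition and higher numbers for weaker inhibition), compound 1 gives 4890 nM. For compound 2 the outcome in this assay is recorded as "not determined" (no result reported), so no number stands beside it. Compound 3 `COc1ncc(-c2ccc3nccc(-c4ccc(Cn5ccnc5)cc4)c3c2)cc1NS(=O)(=O)c1ccc(F)cc1F` differs from compound 2 by 1H-imidazol-1-yl in place of 1H-1,2,4-triazol-1-yl on a saturated chain carbon bound to an aromatic carbon. No step between measured compounds is shown, so the expectation for compound 3 rests only on compound 1 and its value 4890 nM in this assay, and any shift beyond the scatter in either direction remains open. Compound 3 is therefore estimated at 5000 nM, within 1000 nM to 25000 nM.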

Compound 3, half-maximal inhibitory concentration: 600 nM
Compound 3: middle estimate off by 8.3-fold (0.92 log units), on the high side; measured number outside the range, below it.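

On a saturated chain carbon bound to an aromatic carbon, 1H-imidazol-1-yl in place of diethylamino gives an 8.2-fold lower number from compound 1 to compound 3 (0.91 log units; beyond the scatter) in this assay, which shows that the number moves with the group held at this position. The step from compound 2 to compound 3 cannot be read, so the 1H-1,2,4-triazol-1-yl group has no place in this comparison. Nothing at hand accounts for the shift.

From the compounds shown here alone, it remains open how a morpholine or a carboxylic acid at this position would compare with 1H-imidazol-1-yl.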